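Ester Removal on Two Cores in a Cytotoxicity Assay

This account rests on a few compounds, and the source may have more. Where it says the series, first, only, none or still open, it means among the compounds named here.

Compound 1 `CC(=O)OCCCc1cnc2ncnn2c1`: 0%
Compound 2 `CCn1ncc2cc(CCCOC(C)=O)cnc21`: 13%
Compound 3 `OCCCc1cnc2ncnn2c1`: 0%

In a functional assay on THP-1 cells (Homo sapiens) for cytotoxicity, tested at 10 uM (on this read-out lower numbers stand for less inhibition and higher numbers for more inhibition at the one concentration tested (going by the name of the read-out)), compound 1 gives 0% and compound 3 gives 0%. The two differ by hydrogen in place of acetyl on an oxygen on a saturated carbon, and the step of no change at the digits printed from compound 1 to compound 3 (within the scatter) shows that this change leaves the read-out where it was. Compound 2, built on a different core, gives 13% in this assay; the difference between the two cores is not broken down here. Compound 2 stands highest of the three, beyond the scatter from both compound 1 and compound 3.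

Compound 4 `CCn1ncc2cc(CCCO)cnc21` has not yet been measured. It differs from compound 2 by hydrogen in place of acetyl on an oxygen on a saturated carbon, the same change that leads from compound 1 to compound 3, at the same kind of place. Because the step of no change at the digits printed from compound 1 to compound 3 (within the scatter) was flat on the core of compound 1, the step expected from compound 2 to compound 4 is likewise small, about a number 2 percentage points lower from compound 2 to compound 4 (within the scatter). Compound 4 is therefore estimated at 11% in this assay, most likely between 0% and 25%.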

Compound 4, a percentage reported as inhibition, at one concentration (the size of the read-out at that concentration, not a potency): 8%
For compound 4 the middle estimate is 3 percentage points above the measured one; low and high end bracket the measured number.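

On the second core, hydrogen in place of acetyl on the oxygen gives a number 5 percentage points lower from compound 2 to compound 4 (within the scatter). Set beside the first case in this assay, the two steps agree: the same change on two cores in this assay, no change at the digits printed (within the scatter) from compound 1 to compound 3 and a number 5 percentage points lower (within the scatter) from compound 2 to compound 4, 5 percentage points apart, within the scatter of two such steps. This shows that, for these two pairs, the change carries from the core of compound 1 to the core of compound 2 without a step that stands out from the scatter on either core, but it does not establish a rule for other cores, nor does it show how the change would behave on a compound with a much larger read-out, since compound 2 starts at only 13%.

The compounds shown leave open what a different group on that oxygen would do, such as a methyl ether or a benzoyl ester. They also leave open whether an amine or a carboxylic acid at the end of the chain, or a longer chain, would move the read-out on either core.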